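From Phenyl to Phenoxy at the Limit

A few compounds are considered here, and "the series" means these few. Any claim that something is new, unique, unknown or untested is made for them only; others in the source may bear on it.

In an ADME assay on HEK293 cells (Homo sapiens) for cytotoxicity, read by luminescence, with a stated time of 72 h (a higher number here means that more compound is needed for the effect, a lower number that less compound is needed), compound 1 (`CCOC(=O)c1c(-c2cccc(-c3ccccc3)c2)[nH]c2cc(OC)ccc2c1=O`) gives > 22000 nM as a limit of the assay and not a number. Compound 2 (`CCOC(=O)c1c(-c2cccc(CO)c2)[nH]c2cc(OC)ccc2c1=O`) also gives only the limit > 22000 nM and no number. Compound 3 (`CCOC(=O)c1c(-c2cccc(-c3ccccc3)c2)[nH]c2cc(OC)c(OC)cc2c1=O`) likewise stands at the limit > 22000 nM and has no readable place in the set. The three results therefore tell one story (the limit of > 22000 nM in this assay, at which 3 of the 3 values shown sit) and give no ranking.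

Compared with compound 3, compound 4 (`CCOC(=O)c1c(-c2cccc(Oc3ccccc3)c2)[nH]c2cc(OC)c(OC)cc2c1=O`) carries phenoxy in place of phenyl on an aromatic carbon, meta to a large group (phenoxy in place of phenyl on an aromatic carbon). For the measured compounds named here, two measured steps bear on this only loosely, since neither is the same change. Hydroxymethyl in place of phenyl on an aromatic carbon makes a step that the two limits leave unreadable from compound 1 to compound 2 and methoxy in place of hydrogen on an aromatic carbon makes a step that the two limits leave unreadable from compound 1 to compound 3 so neither offers a size to carry over.

The limit of compound 3 (> 22000 nM) is the only anchor, and no step beyond the scatter is expected in this assay from this swap. The expected outcome is a step that the limit leaves unreadable from compound 3 to compound 4 on this estimate. Compound 4 is estimated at 25000 nM with an expected range from 14000 nM to 44000 nM and may well report only a limit.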

Compound 4, half-maximal effective concentration: > 22000 nM
Compound 4: no number, only a limit; the forecaster's own chance of this, stated with the estimate: 85%; the middle value is on the limit's open side.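

In this assay compound 4 gives > 22000 nM, a limit of the assay and not a number. Compound 3 also stands at a limit, so no step can be read between compound 3 and compound 4, and the set shows one thing only: the limit of > 22000 nM in this assay, at which 4 of the 4 values shown sit. The compounds shown leave open how phenoxy and phenyl compare in this assay, as none of them has a readable number.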